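The source may report more compounds than this note shows. Statements on the series, on what has been measured and on what is new or still open speak of the compounds shown alone.

Working notes on the series. Compound 1 `CCOc1ccc(-c2c(NC(=O)c3ccccc3)c(C(=O)O)nn2-c2ccc(Oc3ccccc3)cc2)cc1` gives 1130 nM in an assay for displacement of a labelled ligand from E3 ubiquitin-protein ligase Mdm2 (Homo sapiens), read by fluorescence polarization, with a stated time of 30 min; on this read-out higher numbers stand for weaker inhibition and lower numbers for stronger inhibition. Compound 2 `CCOc1ccc(-c2c(NC(=O)c3ccc(C(C)(C)C)cc3)c(C(=O)O)nn2-c2ccc(Oc3ccccc3)cc2)cc1` gives 689 nM in this assay, and the step of a 1.6-fold lower number from compound 1 to compound 2 (0.21 log units; within the scatter) is within the scatter, so on the two numbers shown compound 2 and compound 1 are not separated; compound 2 simply stands at the value quoted. The compound still to be measured is compound 3 `CCOc1ccc(-c2c(NC(=O)c3ccc(OC(C)C)cc3)c(C(=O)O)nn2-c2ccc(Oc3ccccc3)cc2)cc1`. The change is isopropoxy in place of tert-butyl on an aromatic carbon, para to a large group; cut one bond further out it reads 4-(tert-butyl)phenyl to 4-isopropoxyphenyl. Going by the values given here, only one measured step touches this position, a 1.6-fold lower number from compound 1 to compound 2 (0.21 log units; within the scatter), and it stayed within the scatter; no measured pair separates tert-butyl from isopropoxy. The step of a 1.1-fold higher number from compound 2 to compound 3 (0.04 log units; within the scatter) is therefore expected to stay within the scatter, with no direction claimed. Compound 3 is estimated at 750 nM in this assay, with a range of 300 nM to 1900 nM.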

Compound 3, inhibition constant: 301 nM
Compound 3: the middle estimate sits 2.5-fold (0.40 log units) above what was measured; the range from low to high includes it.
By their numbers in this assay, from the lowest: compound 3; then compounds 2 and 1 (each within the scatter of the next).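

In this assay, going by these compounds alone, the step of a 2.3-fold lower number from compound 2 to compound 3 (0.36 log units; beyond the scatter) is the first at this position to go beyond the scatter, and it separates two groups that the earlier compounds could not: isopropoxy, which carries an oxygen and a hydrogen-bond acceptor, and tert-butyl, which carries neither. Against hydrogen, the step of a 3.8-fold lower number from compound 1 to compound 3 (0.57 log units; beyond the scatter) also goes beyond the scatter, whereas the step of a 1.6-fold lower number from compound 1 to compound 2 (0.21 log units; within the scatter) did not, so on these three compounds the identity of the group at this position shows in the read-out, though only modestly. Nothing available here bears on why isopropoxy gives the lower number.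

Going by these compounds, what remains open is whether the oxygen or the branched chain carries the difference. A methoxy, a longer alkoxy chain or an amine on the same aromatic carbon would test this, and compounds 1 to 3 do not show how far the trend extends beyond isopropoxy.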